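The compounds below may be only part of what the source reports. "The series", "measured", "known", "first", "only" and "open" are said of these compounds alone.

Compound 1 `C=CCn1c(=O)/c(=C\c2ccccc2Cl)[nH]c(=O)/c1=C\c1ccccc1OC`: in a functional assay on MOLT-4 cells (Homo sapiens) for cytotoxicity, read by CCK-8 assay, with a stated time of 72 h (a higher number here means a weaker inhibitor, a lower number a stronger inhibitor), compound 1 gives 4400 nM.
Compound 2 `C=CCn1c(=O)/c(=C\c2ccccc2OC)[nH]c(=O)/c1=C\c1ccccc1OC`: in this assay compound 2 gives 13100 nM.

Compound 2 stands highest of the two numbers; its nearest neighbour, compound 1, lies beyond the scatter below it. Compound 3 `C=CCn1c(=O)/c(=C\c2ccc(F)c(Br)c2)[nH]c(=O)/c1=C\c1ccccc1OC` differs from compound 2 by 3-bromo-4-fluorophenyl in place of 2-methoxyphenyl on a double-bonded chain carbon bound to an aromatic carbon. Going by the values given here, the one step measured, a 3.0-fold higher number from compound 1 to compound 2 (0.47 log units; beyond the scatter), bears on it only loosely: there a halogen gave way to methoxy and the number rose. Here methoxy gives way to a dihalogenated ring, though in a different substitution pattern, so a modest drop in the number is expected, a 2.2-fold lower number from compound 2 to compound 3 (0.34 log units; beyond the scatter). Compound 3 is therefore estimated at 6000 nM, within 2500 nM to 15000 nM.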

Compound 3, half-maximal inhibitory concentration: "not active" (no number reported)
Compound 3: no number reported; the estimate stays without a comparison.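

Going by these compounds alone, compound 3 carries no number in this assay, so no step from compound 2 to compound 3 can be read. The compounds shown leave open how far 3-bromo-4-fluorophenyl shifts the number relative to 2-methoxyphenyl. No supporting data bear on this result.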